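A few compounds are considered here, and "the series" means these few. Any claim that something is new, unique, unknown or untested is made for them only; others in the source may bear on it.

Working notes on the series.

Compound 1 `CC(NC(=O)/C=C/c1ccc(NC(=O)Nc2ccc(Cl)c(C(F)(F)F)c2)cc1)c1ccccc1` is the parent of the pair under study. In a functional assay on KETR3 cells (Homo sapiens) for inhibition, read by MTT assay, with a stated time of 120 h (a higher number here means a weaker inhibitor, a lower number a stronger inhibitor), compound 1 gives 21200 nM. Two further measured compounds share a second core: compound 3 `CC(NC(=O)/C=C/Oc1ccc(NC(=O)Nc2ccc(Cl)c(C(F)(F)F)c2)cc1)c1ccccc1` gives 14500 nM in this assay, and compound 2 `CC(NC(=O)/C=C/Oc1ccc(NC(=O)Nc2cc(C(F)(F)F)ccc2Cl)cc1)c1ccccc1` gives 16400 nM in this assay. Against compound 1, the two values of compound 3 and compound 2 lie within the scatter of the measurement. The difference between the core of compound 1 and the core of compound 3 is not broken down here.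

Within the second core, the change from compound 3 to compound 2 is 2-chloro-5-(trifluoromethyl)phenyl in place of 4-chloro-3-(trifluoromethyl)phenyl on an amide-type nitrogen. It made a 1.1-fold higher number from compound 3 to compound 2 (0.05 log units; within the scatter).

Compound 4 `CC(NC(=O)/C=C/c1ccc(NC(=O)Nc2cc(C(F)(F)F)ccc2Cl)cc1)c1ccccc1` is not yet measured. It carries the same change on the core of compound 1: 2-chloro-5-(trifluoromethyl)phenyl in place of 4-chloro-3-(trifluoromethyl)phenyl on an amide-type nitrogen. The place of the change reads identically for both pairs, so it is the same change, seen twice among the compounds shown. Because the earlier step was a 1.1-fold higher number from compound 3 to compound 2 (0.05 log units; within the scatter), the step from compound 1 to compound 4 is expected to be likewise small, estimated as a 1.1-fold higher number from compound 1 to compound 4 (0.04 log units; within the scatter). Compound 4 is therefore estimated at 23000 nM in this assay, expected between 11000 nM and 46000 nM.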

Compound 4, half-maximal inhibitory concentration: 14300 nM
Compound 4: middle estimate off by 1.6-fold (0.21 log units), on the high side; measured number inside the range.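

In this assay, putting 2-chloro-5-(trifluoromethyl)phenyl in place of 4-chloro-3-(trifluoromethyl)phenyl on an amide-type nitrogen gives a 1.5-fold lower number from compound 1 to compound 4 (0.17 log units; within the scatter), so on the core of compound 1, as on the second core, this change stays inside the usual scatter. Set side by side, the two steps do not differ: the same change on two cores in this assay, a 1.1-fold higher number (0.05 log units; within the scatter) from compound 3 to compound 2 and a 1.5-fold lower number (0.17 log units; within the scatter) from compound 1 to compound 4, 1.7-fold (0.22 log units) apart, within the scatter of two such steps. This shows that, for these two cores, the change carried over as a small step with no detectable dependence on the core, but it does not show that the step has a real direction or that the same would hold on any other core.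

The compounds shown leave open whether a phenyl carrying a nitrile or a carboxylic acid, in place of either group on that amide-type nitrogen, would give a step beyond the scatter. They also leave open whether any such step would carry from one core to the other.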